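Halogen removal on the aryl ring: working notes

The source may hold more compounds than are shown below. What is called first, only, known or untested is meant among the compounds shown, and "the series" means these compounds.

Measured so far:
compound 1 `O=C1COc2ccc(-c3nn(-c4ccc(Cl)cc4)cc3-c3ccccc3)cc2N1` — 61.9%
compound 2 `O=C1COc2ccc(-c3nn(-c4ccc(F)cc4)cc3-c3ccccc3)cc2N1` — 64.4%

Going by the values given here, in a functional assay on DLD-1 cells (Homo sapiens) for cytotoxicity, read by colorimetric assay and MTT assay, with a stated time of 3 days, tested at 1 uM (a lower number here means a stronger effect, a higher number a weaker effect of the compound at the concentration tested), compound 2 holds the higher of the two numbers, though the only measured step, a number 2.5 percentage points higher from compound 1 to compound 2 (within the scatter), lies within the scatter. Compound 3 `O=C1COc2ccc(-c3nn(-c4ccccc4)cc3-c3ccccc3)cc2N1` is not yet measured. Change from compound 2: hydrogen in place of fluoro on an aromatic carbon. Among the compounds with values here, the sole measured step swaps one halogen for another, and that step was a number 2.5 percentage points higher from compound 1 to compound 2 (within the scatter); no measured step removes a halogen altogether. The expected step is therefore a number 0.4 percentage points lower from compound 2 to compound 3 (within the scatter), that is none beyond the scatter. Compound 3 is estimated at 64%, with a range from 54% to 74%.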

Compound 3, a percentage reported as activity, at one concentration (the size of the read-out at that concentration, not a potency): 77%
Compound 3: the middle estimate sits 13 percentage points below what was measured; measured number outside the range, above it.
By their numbers in this assay, from the lowest: compounds 1 and 2 (each within the scatter of the next); then compound 3.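

Taking the halogen off altogether does what swapping one halogen for another did not: a number 12.6 percentage points higher from compound 2 to compound 3 (beyond the scatter) and a number 15.1 percentage points higher from compound 1 to compound 3 (beyond the scatter) in this assay are both beyond the scatter. At this place, para to a large group, either fluoro or chloro thus gives a lower number than hydrogen, while the two halogens stay within the scatter of each other. Nothing at hand explains this difference.

Open, on these data alone, is how a methoxy group or an amine at this place would compare with the halogens and hydrogen. Also open, as far as these compounds go, is whether the same change on the other phenyl ring would give a similar step.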